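Aryl and linker change at the diaminoquinoxaline core

This account rests on a few compounds, and the source may have more. Where it says the series, first, only, none or still open, it means among the compounds named here.

Measured so far in a functional assay on COLO 205 cells (Homo sapiens) for inhibition, read by sulforhodamine B assay, with a stated time of 48 h; a higher number here means a weaker inhibitor of growth, a lower number a stronger inhibitor of growth:
- compound 1 `Nc1cc(N)c2nc(-c3ccccc3)c(NCc3ccc(Cl)c(Cl)c3)nc2c1`: 33900 nM
- compound 2 `COc1ccc(CNc2nc3cc(N)cc(N)c3nc2-c2ccccc2)cc1OC`: a limit only, < 100000 nM
- compound 3 `Nc1cc(N)c2nc(-c3ccccc3)c(NCc3ccc(F)cc3)nc2c1`: 6170 nM

Among the compounds with values here, compound 3 carries the lowest of the two numbers; its nearest neighbour is compound 1, with a 5.5-fold lower number from compound 1 to compound 3 (0.74 log units; beyond the scatter) being the only step whose size can be read. For compound 2 the assay reports a limit, < 100000 nM, and nothing more. The steps a step that the limit leaves unreadable from compound 1 to compound 2 and a step that the limit leaves unreadable from compound 2 to compound 3 therefore have no readable size, and that value sits at the limit of < 100000 nM in this assay, at which 1 of the 3 values shown sits.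

Compound 4 `Nc1cc(N)c2nc(-c3ccccc3)c(Sc3ccc(Cl)c(Cl)c3)nc2c1` differs from compound 3 by (3,4-dichlorophenyl)sulfanyl in place of (4-fluorobenzyl)amino on an aromatic carbon. Two things change at once. The aryl goes back from 4-fluorophenyl to 3,4-dichlorophenyl, the reverse of what happened in a 5.5-fold lower number from compound 1 to compound 3 (0.74 log units; beyond the scatter), so that part alone would be expected to push the number up by a similar margin. Within the data shown here, the second part, a sulfanyl link in place of the benzylamino link, has no measured counterpart among compounds 1 to 3, so its contribution is unknown. Taken together, compound 4 is expected to land near the value of compound 1, a step of a 4.9-fold higher number from compound 3 to compound 4 (0.69 log units; beyond the scatter). The estimate for compound 4 is 30000 nM, with a range from 8000 nM to 100000 nM.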

Compound 4, concentration for total growth inhibition: 33900 nM
Compound 4: the middle estimate sits 1.1-fold (0.05 log units) below what was measured, within the range that was stated.
By their numbers in this assay, from the lowest: compound 3; then compounds 1 and 4 (each within the scatter of the next).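

Working from the new step, the swap at this aromatic carbon gives a 5.5-fold higher number from compound 3 to compound 4 (0.74 log units; beyond the scatter) with the aryl and the link changing together, so this step alone cannot be split between the two parts. Both compounds with the 3,4-dichlorophenyl group print the same number in this assay, compound 1 with 33900 nM and compound 4 with 33900 nM as well, so with this aryl the sulfanyl link and the benzylamino link show no difference here, even though the entering group carries 0 hydrogen-bond donors. Nothing measured here gives a reason for this outcome.

Open, from the compounds shown here alone, is whether the 4-fluorophenyl group keeps its lower number on a sulfanyl link. Also open, going by these compounds, is how an ether oxygen link or a longer chain between the core and the aryl would read.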